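The compounds below may be only part of what the source reports. "The series", "measured", "known", "first", "only" and "open" are said of these compounds alone.

Three measured compounds define the set. Compound 1 `COc1cccc(CNCCCNc2ccnc3cc(Oc4ccccc4)ccc23)c1O` gives 6800 nM in an ADME assay on HepG2 cells (Homo sapiens) for cytotoxicity, read by luminescence, CellTiter-Glo and ATP content, with a stated time of 72 h; a higher number here means that more compound is needed for the effect, a lower number that less compound is needed. Compound 3 `COc1cccc(CNCCCNc2ccnc3cc(CCC(C)C)ccc23)c1O` gives 5390 nM in this assay. Compound 2 `FC(F)(F)c1ccc(-c2ccc3c(NCCCNCc4ccco4)ccnc3c2)cc1` gives 3470 nM in this assay, the lowest of the three numbers, though its gaps to compound 3 and to compound 1 both lie within the scatter, so no order among the three can be claimed.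

One step is measured: a 1.3-fold lower number from compound 1 to compound 3 (0.10 log units; within the scatter). Within the data shown here, that is the only comparison in which an aromatic substituent is replaced by a branched alkyl chain on the shared core, and it bears directly on the step to compound 4 `CCC(CC)c1ccc2c(NCCCNCc3ccco3)ccnc2c1`, where (pentan-3-yl in place of 4-(trifluoromethyl)phenyl on an aromatic carbon). Given that the step from compound 1 to compound 3 stayed within the scatter, no step beyond the scatter is expected in this assay for compound 4 either, in neither direction; the expected step is a 1.2-fold higher number from compound 2 to compound 4 (0.06 log units; within the scatter). Compound 4 is therefore estimated at 4000 nM in this assay, with a range from 2000 nM to 8500 nM.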

Compound 4, half-maximal effective concentration: 6760 nM
Compound 4: middle estimate off by 1.7-fold (0.23 log units), on the low side, within the range that was stated.
By their numbers in this assay, from the lowest: compounds 2, 3, 4 and 1 (each within the scatter of the next).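

In this assay, the change at this aromatic carbon gives a 1.9-fold higher number from compound 2 to compound 4 (0.29 log units; within the scatter), even though 4-(trifluoromethyl)phenyl, with 10 heavy atoms and one six-membered aromatic ring, gives way to pentan-3-yl, with 5 heavy atoms and no ring. Alongside a 1.3-fold lower number from compound 1 to compound 3 (0.10 log units; within the scatter), this makes two steps in which a ring-bearing group on an aromatic carbon gives way to a branched alkyl chain, on different side chains, with neither step beyond the scatter and no compound going against this. No measurement at hand accounts for either step.

Open, from the compounds shown here alone, is whether a group of another kind at this carbon, such as a carboxylic acid or a primary amine, would give a step beyond the scatter in this assay. A straight pentyl chain at this carbon would show whether the branching matters at all.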